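Anilino para substituent swap: chloro to methoxy

The source may hold more compounds than are shown below. What is called first, only, known or untested is meant among the compounds shown, and "the series" means these compounds.

Among the compounds with values here, compound 2 `CCOC(=O)/C(=C\c1ccc(B(O)O)cc1)C(=O)c1sc(Nc2ccc(Cl)cc2)nc1N(C)C` carries the lowest of the two numbers so far in a functional assay on MDA-MB-231 cells (Homo sapiens) for inhibition, read by MTT assay (on this read-out lower numbers stand for stronger inhibition and higher numbers for weaker inhibition), where compound 2 gives 34900 nM. Its nearest neighbour is compound 1 `CCOC(=O)/C(=C\c1ccc(B(O)O)cc1)C(=O)c1sc(Nc2ccccc2)nc1N(C)C`, which in this assay gives 38000 nM; the step of a 1.1-fold lower number from compound 1 to compound 2 (0.04 log units; within the scatter) lies within the scatter, so the two compounds are not separated on this read-out.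

Compound 3 `CCOC(=O)/C(=C\c1ccc(B(O)O)cc1)C(=O)c1sc(Nc2ccc(OC)cc2)nc1N(C)C` is the next member of the series. Relative to compound 2 the change is methoxy in place of chloro on an aromatic carbon.

Within the data shown here, only one measured step bears on this place: a 1.1-fold lower number from compound 1 to compound 2 (0.04 log units; within the scatter), chloro in place of hydrogen on an aromatic carbon, which did not move the number beyond the scatter. Among the measured compounds shown here, no measured pair shows methoxy at this place, so the expectation rests on that single step, which indicates that a substituent para to a large group on this ring leaves the read-out in this assay unchanged. The estimated step of a 1.0-fold higher number from compound 2 to compound 3 (0.00 log units; within the scatter) is therefore expected to stay within the scatter, with no clear direction. Compound 3 is expected to give 35000 nM in this assay, with a range from 15000 nM to 80000 nM.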

Compound 3, half-maximal inhibitory concentration: 58700 nM
Compound 3: middle estimate off by 1.7-fold (0.22 log units), on the low side; measured number inside the range.
By their numbers in this assay, from the lowest: compounds 2, 1 and 3 (each within the scatter of the next).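

In this assay, methoxy now stands at the aromatic carbon para to a large group, giving a 1.7-fold higher number from compound 2 to compound 3 (0.23 log units; within the scatter) and a 1.5-fold higher number from compound 1 to compound 3 (0.19 log units; within the scatter), both within the scatter. Hydrogen, chloro and methoxy at this place are therefore not separated on this read-out, and the earlier chloro-for-hydrogen step no longer stands alone: a group with oxygen and a hydrogen-bond acceptor, which chloro lacks, also leaves the number within the scatter of both neighbours. No measurement shown here gives a reason for this flat picture.

The compounds shown leave open whether any group at this place can move the number beyond the scatter, for instance an amine, a carboxylic acid or a longer chain such as butoxy, since the three groups in hand span only a narrow set of substituents on this ring. They also leave open whether the weak inhibition seen across the series depends on other parts of the shared core, such as the boronic acid or the ethyl ester, neither of which varies among compounds 1, 2 and 3.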